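Extending the Methyl on Compound 2 into a Longer Chain

The compounds below may be only part of what the source reports. "The series", "measured", "known", "first", "only" and "open" are said of these compounds alone.

Measured so far:
compound 1 `COc1cc(C(=O)c2ccc3cc[nH]c3c2)cc(OC)c1OC` — 452 nM
compound 2 `COc1cc(C(=O)c2ccc3c(ccn3C)c2)cc(OC)c1OC` — 12.5 nM

Of the compounds shown here, two have been tested in a functional assay (Homo sapiens) for inhibition, with a stated time of 72 h; a lower number here means a stronger inhibitor, a higher number a weaker inhibitor. Compound 1 gives 452 nM, while compound 2 gives 12.5 nM. Compound 2 therefore stands at the lowest of the two numbers, and the gap to compound 1 is far beyond the usual scatter, so compound 2 is clearly the stronger inhibitor of the pair.

Compound 3 `COc1cc(C(=O)c2ccc3c(ccn3CCN(C)C)c2)cc(OC)c1OC` has not yet been measured. It differs from compound 2 in one place: (dimethylamino)methyl in place of hydrogen on a saturated chain carbon bound to an aromatic nitrogen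

Within the data shown here, nothing measured here speaks directly to what such a chain does, since the only comparison available concerns the change between compound 1 and compound 2. The expectation is a modest step from compound 2 to compound 3 toward a higher number, perhaps not beyond the scatter, given as a 2.0-fold higher number from compound 2 to compound 3 (0.30 log units; within the scatter). Compound 3 is thus estimated to give 25 nM, with a likely range from 5 nM to 150 nM.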

Compound 3, half-maximal inhibitory concentration: 4900 nM
For compound 3 the middle estimate is 200-fold (2.29 log units) below the measured one, outside the stated range (above it).
By their numbers in this assay, from the lowest: compound 2; then compound 1; then compound 3.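

In this assay, exchanging the methyl bound to the aromatic nitrogen for a 2-(dimethylamino)ethyl chain brings a drop in inhibition, with a 390-fold higher number from compound 2 to compound 3 (2.59 log units; beyond the scatter) and a size well beyond the scatter. The earlier pair had shown only that compound 1 gives 452 nM and compound 2 gives 12.5 nM, so the new result adds something they could not: this position does not accept every larger group, and a single change here can cost most of the strength that compound 2 has. The data show that the loss occurs, but no measurement here accounts for it.

The change from compound 2 to compound 3 adds both a longer chain and an amine at once, so the compounds shown cannot separate the two. A plain ethyl or propyl group would test the chain without the amine, while a 2-hydroxyethyl chain or a morpholine ring at the end of the chain would show whether another end group fares any better.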